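The source may hold more compounds than are shown below. What is called first, only, known or untested is meant among the compounds shown, and "the series" means these compounds.

Compound 3 `c1ccc(COc2ccc(OCCOCCNc3ccncc3)cc2)cc1` gives 20600 nM in a functional assay on SK-OV-3 cells (Homo sapiens) for inhibition, read by CCK-8 assay, with a stated time of 70 h (a lower number here means a stronger inhibitor, a higher number a weaker inhibitor), the higher of the two numbers there. Its nearest neighbour is compound 1 `Clc1ccc(COc2ccc(OCCOCCNC3CCCC3)cc2)cc1`, which gives 7670 nM. Compound 2 `c1ccc(COc2ccc(OCCOCCNc3ccccc3)cc2)cc1` reports only a limit, > 100000 nM. Among the compounds with values here, the single measured step, an at least 4.8-fold lower number from compound 2 to compound 3 (0.68 log units; beyond the scatter), is the only change so far that touches the same amine nitrogen. Compound 4 `c1ccc(COc2ccc(OCCOCCNC3CCCC3)cc2)cc1` is the next structure; its change from compound 3 is cyclopentyl in place of pyridin-4-yl on an amine nitrogen. Within the data shown here, no measured step covers this change directly. Compound 1 also carries a cyclopentyl on its amine nitrogen and gives 7670 nM, so the number for compound 4 is expected to fall near that. Compound 4 is thus expected to show a step of a 2.6-fold lower number from compound 3 to compound 4 (0.41 log units; beyond the scatter). The estimate for compound 4 is 8000 nM, between 3000 nM and 25000 nM.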

Compound 4, half-maximal inhibitory concentration: 24800 nM
For compound 4 the middle estimate is 3.1-fold (0.49 log units) below the measured one, and the stated range covers the measured number.
By their numbers in this assay, from the lowest: compound 1; then compounds 3 and 4 (each within the scatter of the next). At a limit, above all of these: compound 2.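

With a 1.2-fold higher number from compound 3 to compound 4 (0.08 log units; within the scatter) in this assay, cyclopentyl and pyridin-4-yl on the amine nitrogen cannot be told apart, and an at least 4.0-fold lower number from compound 2 to compound 4 (0.60 log units; beyond the scatter) shows that cyclopentyl, like pyridin-4-yl, improves on phenyl there. Compound 2 counts only as a limit: (the limit of > 100000 nM in this assay, at which 1 of the 4 values shown sits). The chloro on the aromatic carbon also matters with cyclopentyl held fixed, as hydrogen in its place gives a 3.2-fold higher number from compound 1 to compound 4 (0.51 log units; beyond the scatter) in the same assay.

Going by these compounds, whether chloro has the same effect with pyridin-4-yl or phenyl on the nitrogen remains open. So does how an open-chain isopropyl, a cyclohexyl or a pyridin-3-yl would fare at that nitrogen.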